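A few compounds are considered here, and "the series" means these few. Any claim that something is new, unique, unknown or untested is made for them only; others in the source may bear on it.

Measured so far:
compound 1 `CN(CC1=CC[C@H]2C[C@@H]1C2(C)C)Cc1ccc(-c2cccc(C(F)(F)F)c2)cc1` — > 316 nM
compound 2 `COC(=O)c1cccc(-c2ccc(CN(C)CC3=CC[C@H]4C[C@@H]3C4(C)C)cc2)c1` — > 316 nM

In an assay on HEK293 cells for displacement of a labelled ligand from C-X-C chemokine receptor type 3 (Homo sapiens) (on this read-out lower numbers stand for stronger inhibition and higher numbers for weaker inhibition), compound 1 gives > 316 nM, a limit of the assay and not a number. Compound 2 gives > 316 nM, likewise a limit. The step that the two limits leave unreadable from compound 1 to compound 2 therefore has no readable size; both values sit at the limit of > 316 nM in this assay, at which 2 of the 2 values shown sit. Compound 2 thus stands only at a limit, with no number of its own.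

Compound 3 `Cc1cccc(-c2ccc(CN(C)CC3=CC[C@H]4C[C@@H]3C4(C)C)cc2)c1` differs from compound 2 by methyl in place of methoxycarbonyl on an aromatic carbon, meta to a large group. Among the compounds with values here, only the step from compound 1 to compound 2 touches this position, and it is unreadable, so nothing measured sets the size of the change. The step that the limit leaves unreadable from compound 2 to compound 3 is expected to stay within the scatter in this assay. The estimate for compound 3 is 600 nM, expected between 200 nM and 3000 nM, most likely again a limit.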

Compound 3, inhibition constant: > 316 nM
Compound 3 gave a limit, no number; the forecaster's own chance of this, stated with the estimate: 70%; the middle value does not contradict the limit.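

In this assay compound 3 gives > 316 nM, a limit and not a number. No step among compound 1, compound 2 and compound 3 can be read: the limit of > 316 nM in this assay, at which 3 of the 3 values shown sit.

The compounds shown leave open whether trifluoromethyl, methoxycarbonyl and methyl on this aromatic carbon differ at all on this read-out.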